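The source may report more compounds than this note shows. Statements on the series, on what has been measured and on what is new or still open speak of the compounds shown alone.

Measured compounds:
compound 1 `Cc1cn([C@@H]2O[C@H](CO[Si](C)(C)C(C)(C)C)[C@@]3(OS(=O)(=O)C=C3NCCC(=O)OCc3ccccc3)[C@H]2O[Si](C)(C)C(C)(C)C)c(=O)n(C)c1=O` — > 250000 nM, a limit of the assay.
compound 2 `Cc1cn([C@@H]2O[C@H](CO[Si](C)(C)C(C)(C)C)[C@@]3(OS(=O)(=O)C=C3NCCC(N)=O)[C@H]2O[Si](C)(C)C(C)(C)C)c(=O)n(C)c1=O` — 20000 nM.
compound 3 `COC(=O)CCNC1=CS(=O)(=O)O[C@@]12[C@@H](CO[Si](C)(C)C(C)(C)C)O[C@@H](n1cc(C)c(=O)n(C)c1=O)[C@@H]2O[Si](C)(C)C(C)(C)C` — > 250000 nM, a limit of the assay.

All three share one core and differ only in the group hanging from the amine nitrogen. In a functional assay on MT4 cells (Homo sapiens) (a higher number here means that more compound is tolerated, a lower number that less compound is tolerated), compound 3 sits at the limit of > 250000 nM in this assay, at which 2 of the 3 values shown sit, so only a limit is known for it, not a number. The next compound, compound 4 `CC(=O)NC1=CS(=O)(=O)O[C@@]12[C@@H](CO[Si](C)(C)C(C)(C)C)O[C@@H](n1cc(C)c(=O)n(C)c1=O)[C@@H]2O[Si](C)(C)C(C)(C)C`, is not yet measured; it differs from compound 3 by acetyl in place of 2-(methoxycarbonyl)ethyl on an amine nitrogen.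

Three measured steps give some footing. Replacing the ester of compound 1 by a simple carboxamide gave an at least 12-fold lower number from compound 1 to compound 2 (1.09 log units; beyond the scatter), and going from that carboxamide back to an ester gave an at least 12-fold higher number from compound 2 to compound 3 (1.09 log units; beyond the scatter). Between the two esters the step is a step that the two limits leave unreadable from compound 1 to compound 3. So the one compound carrying an amide rather than an ester, compound 2, is also the one for which less compound is tolerated. Compound 4 again carries an amide, now directly on the nitrogen, so a lower number than the limit of compound 3 is expected, though a result at the limit remains quite possible. Compound 4 is therefore estimated at 100000 nM (range 20000 nM to 250000 nM), an expected step of an at least 2.5-fold lower number from compound 3 to compound 4 (0.39 log units; beyond the scatter).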

Compound 4, half-maximal cytotoxic concentration: 10700 nM
The estimate for compound 4 lay 9.3-fold (0.97 log units) above the measured number; the whole stated range lies above it.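

In this assay, putting an acetyl group on the amine nitrogen gives an at least 23-fold lower number from compound 3 to compound 4 (1.36 log units; beyond the scatter) and an at least 23-fold lower number from compound 1 to compound 4 (1.36 log units; beyond the scatter), and both sizes are only lower bounds, as the two esters give no number to start from: the limit of > 250000 nM in this assay, at which 2 of the 4 values shown sit. The step to the other amide is different, with a 1.9-fold lower number from compound 2 to compound 4 (0.27 log units; within the scatter), so the acetyl group and the 2-carbamoylethyl group cannot be told apart at this position, even though one has its carbonyl directly on the nitrogen and the other holds it further out on a chain. Across these four compounds, the two with an amide carbonyl, compound 2 and compound 4, are tolerated less than the two esters, compound 1 and compound 3, and no compound shown goes against this pattern.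

Going by these compounds, the step between the two esters cannot be read, so any effect of the benzyl or methyl end of the ester remains unknown. On these data alone, it also remains open whether the amide itself sets the lower number or whether the ester simply raises it, which a carboxylic acid on the same chain, a plain ethyl group on the nitrogen or a longer chain ending in a carboxamide could help to separate.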